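Bromo for chloro on the benzyl ring

The source may report more compounds than this note shows. Statements on the series, on what has been measured and on what is new or still open speak of the compounds shown alone.

Values from a functional assay on DU-145 cells (Homo sapiens) for inhibition, read by trypan blue exclusion, with a stated time of 96 h (on this read-out higher numbers stand for weaker inhibition of growth and lower numbers for stronger inhibition of growth), follow
Compound 1 `O=C(/C(=C\c1ccc(Cl)cc1)SCc1ccc(Cl)cc1)c1ccc(Br)cc1` gives 10000 nM
Compound 2 `O=C(/C(=C\c1ccc(Cl)cc1)SCc1ccc(Cl)cc1)c1ccccc1Cl` gives 30000 nM

Compound 2 holds the higher number of the two. Compound 3 `O=C(/C(=C\c1ccc(Cl)cc1)SCc1ccc(Br)cc1)c1ccccc1Cl` differs from compound 2 by bromo in place of chloro on an aromatic carbon, 4-chlorobenzyl to 4-bromobenzyl. Within the data shown here, the only measured step (a 3.0-fold higher number from compound 1 to compound 2 (0.48 log units; beyond the scatter)) was modest and concerns the group on the carbonyl carbon, so no measurement covers this place. No step beyond the scatter is therefore expected in this assay. The expected step is small (a 1.2-fold lower number from compound 2 to compound 3 (0.08 log units; within the scatter)). For compound 3 the estimated value is 25000 nM with a range from 10000 nM to 60000 nM in this series.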

Compound 3, concentration for 50% growth inhibition: 25000 nM
Compound 3: the middle estimate sits on the measured number at the digits printed; measured number inside the range.
By their numbers in this assay, from the lowest: compound 1; then compounds 3 and 2 (each within the scatter of the next).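

In this assay the change from 4-chlorobenzyl to 4-bromobenzyl, with 2-chlorophenyl held on the carbonyl carbon, gives a step within the scatter (a 1.2-fold lower number from compound 2 to compound 3 (0.08 log units; within the scatter)). The earlier step concerned only the group on the carbonyl carbon, whereas this one shows that the two halogens cannot be told apart at the benzyl position in this pair. No supporting data offer a reason for this result.

From the compounds shown here alone, whether the same swap reads alike with 4-bromophenyl on the carbonyl carbon remains open. So does the outcome of an amine or a carboxylic acid at this benzyl position.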